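The source may report more compounds than this note shows. Statements on the series, on what has been measured and on what is new or still open speak of the compounds shown alone.

Working notes on the series. Compound 1 `CC(C)(C)c1ccc(S(=O)(=O)N[C@H]2CCN(Cc3cc4[nH]cccc-4n3)C2=O)cc1` gives 22% in an assay on isolated protein for inhibition of coagulation factor X (Oryctolagus cuniculus), tested at 1 uM; a lower number here means less inhibition, a higher number more inhibition at the concentration tested (going by the name of the read-out). Going by the values given here, compound 2 `O=C1[C@@H](NS(=O)(=O)c2cc3ccc(Cl)nc3s2)CCN1Cc1cc2[nH]cccc-2n1` gives 23% in the same assay; the step of a number 1 percentage points higher from compound 1 to compound 2 (within the scatter) is the only one-place change measured so far and lies within the scatter. Compound 3 `O=C1[C@@H](NS(=O)(=O)c2ccc(-c3ccncc3)s2)CCN1Cc1cc2[nH]cccc-2n1` gives 35% and stands highest of the three numbers, beyond the scatter from both others, with compound 2 its nearest neighbour and compound 1 furthest.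

Compound 4 `O=C1[C@@H](NS(=O)(=O)c2ccc(-c3ccon3)s2)CCN1Cc1cc2[nH]cccc-2n1` differs from compound 3 by 1,2-oxazol-3-yl in place of pyridin-4-yl on an aromatic carbon. Among the compounds with values here, no measured step exchanges a substituent on the five-membered ring that carries the sulfonyl group; the one measured exchange of the whole sulfonyl aryl group, from compound 1 to compound 2, moved nothing beyond the scatter, while the gap between compound 2 and compound 3 shows that changes on this part can move the read-out beyond it. For compound 4 a step of a number 8 percentage points lower from compound 3 to compound 4 (within the scatter) is therefore expected, a modest fall that may stay inside the scatter. Compound 4 is estimated at 27%, between 12% and 42%.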

Compound 4, a percentage reported as inhibition, at one concentration (the size of the read-out at that concentration, not a potency): 31%
Compound 4: middle estimate off by 4 percentage points, on the low side; measured number inside the range.
By their numbers in this assay, from the lowest: compounds 1, 2, 4 and 3 (each within the scatter of the next, the first and the last beyond it).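

In this assay, the place on an aromatic carbon of a five-membered aromatic ring with 1 sulfur now has its first measured exchange, 1,2-oxazol-3-yl in place of pyridin-4-yl, and the result is a number 4 percentage points lower from compound 3 to compound 4 (within the scatter). Exchanges of the whole group on the sulfonyl sulfur give a number 8 percentage points higher from compound 2 to compound 4 (within the scatter) and a number 9 percentage points higher from compound 1 to compound 4 (within the scatter), so compound 4 lies within the scatter of all three earlier compounds, although compound 3 lies beyond it from compound 1 and compound 2. Nothing measured on these compounds bears on the cause of these steps.

As far as these compounds go, both groups compared at this place are aromatic rings, so the response to an amine or a carboxylic acid there remains open. The read-out is also a single-concentration inhibition, which leaves the potency of these compounds undefined.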